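Two weak compounds and a trifluoromethyl swap

A few compounds are considered here, and "the series" means these few. Any claim that something is new, unique, unknown or untested is made for them only; others in the source may bear on it.

Values in a functional assay on Jurkat cells (Homo sapiens) (a higher number here means a weaker inhibitor, a lower number a stronger inhibitor), for the measured compounds:
- Compound 1 `CC(C)[C@H](NC(=O)COc1cccc2ccccc12)C(=O)N[C@@H](CC(=O)O)C(=O)COc1cccc2ccccc12` gives > 100000 nM as a limit of the assay, not a number
- Compound 2 `CC(C)[C@H](NC(=O)COc1cccc2ccccc12)C(=O)N[C@@H](CC(=O)O)C(=O)COc1ccc(-c2ccccc2)cc1` gives 87900 nM as a measured number

Among the compounds with values here, compound 2 stands at 87900 nM as the only true number so far. The other reading is the limit of > 100000 nM in this assay, at which 1 of the 2 values shown sits, and belongs to compound 1.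

Compound 3 `CC(C)[C@H](NC(=O)COc1cccc2ccccc12)C(=O)N[C@@H](CC(=O)O)C(=O)COc1ccccc1C(F)(F)F` keeps the core of compound 2 and changes one group (2-(trifluoromethyl)phenyl in place of 4-phenylphenyl on an oxygen on a saturated carbon), with 2-(trifluoromethyl)phenyl in place of 4-phenylphenyl on an oxygen on a saturated carbon. Within the data shown here, one measured step bears on this, since it changed the group at the same place (an at least 1.1-fold lower number from compound 1 to compound 2 (0.05 log units; that floor lies within the scatter)). Its size is only a floor, so it shows neither a firm size nor a firm direction. Given compound 2 at 87900 nM and that small step, compound 3 is expected to stay weak in this assay, with at most a modest move towards a lower number. The estimated change is small (a 1.8-fold lower number from compound 2 to compound 3 (0.25 log units; within the scatter)) and may not pass the scatter. For compound 3 the estimated value is 50000 nM within an expected range of 5000 nM to 100000 nM and a reading that gives only a limit is also possible.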

Compound 3, half-maximal inhibitory concentration: > 100000 nM
Compound 3: only a limit was reported; the forecaster's own chance of this, stated with the estimate: 35%; middle value at least 2.0-fold (0.30 log units) from the limit.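

The step reads an at least 1.1-fold higher number from compound 2 to compound 3 (0.05 log units; that floor lies within the scatter), so in this assay replacing 4-phenylphenyl with 2-(trifluoromethyl)phenyl on this oxygen gives neither a firm size nor a firm direction, and the steps between the two limits cannot be read. Compound 3 gives > 100000 nM, which is a limit of the assay and not a number. The new information is that a third group at this place, with one aromatic ring and three fluorines rather than two aromatic rings of carbon only, also gives no reading clear of that limit, so the three groups shown do not separate from one another here: the limit of > 100000 nM in this assay, at which 2 of the 3 values shown sit.

As far as these compounds go, it remains open whether an amine, a carboxylic acid or a longer chain in place of these groups on the oxygen would give a number clearly beyond the scatter from compound 2. The compounds shown also cannot tell how far the shared core, rather than the group at this place, sets these weak readings.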